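Swapping a pyrimidine for an ethyl amide on a shared core

The source may report more compounds than this note shows. Statements on the series, on what has been measured and on what is new or still open speak of the compounds shown alone.

Of the compounds shown here, three of one series have been tested in a functional assay on the whole organism (strain ICR) for inhibition, with Mus musculus as the target, read by scintillation counting, with a stated time of 4 h, at a dose of 10 mg/kg by the oral route; a lower number here means less inhibition, a higher number more inhibition at the dose given (going by the name of the read-out). Compound 1 `Cn1c(-c2ccc(-c3cncnc3)cc2)nnc1C1(c2ccc(Cl)cc2)CCC1` gives 46%, the lowest of the three numbers. Compound 2 `CC(=O)Nc1ccc(-c2nnc(C3(c4ccc(Cl)cc4)CCC3)n2C)c(Cl)c1` gives 79%, and compound 3 `Cn1c(-c2ccc(C(N)=O)cc2Cl)nnc1C1(c2ccc(Cl)cc2)CCC1` gives 57%. Within the data shown here, the only step between two compounds that differ in a single place is a number 22 percentage points lower from compound 2 to compound 3 (beyond the scatter), where a carbamoyl group takes the place of an acetamido group on an aromatic carbon.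

The unmeasured compound 4 `CCNC(=O)c1ccc(-c2nnc(C3(c4ccc(Cl)cc4)CCC3)n2C)cc1` is compound 1 with one change: ethylcarbamoyl in place of pyrimidin-5-yl on an aromatic carbon. The new group sits on an aromatic carbon of a six-membered aromatic ring of carbon only, para to a large group.

Among the measured compounds shown here, no measured step replaces a pyrimidin-5-yl with an amide-type group, so no step bears directly on this change. The nearest hint is that compound 3, which carries a carbamoyl group, gives 57%, which is above the value of compound 1 but well short of compound 2. On that basis compound 4 is expected to land near the middle of the measured range, with an estimated a number 9 percentage points higher from compound 1 to compound 4 (within the scatter) in this assay. Compound 4 is therefore expected to give about 55%, within a range from 30% to 78%.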

Compound 4, a percentage reported as inhibition, in the whole organism at one dose (the size of the read-out at that dose, not a potency): 71%
Beside the measured number, compound 4's estimate is 16 percentage points below it; low and high end bracket the measured number.
By their numbers in this assay, from the lowest: compound 1; then compound 3; then compounds 4 and 2 (each within the scatter of the next).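

In this assay the exchange of pyrimidin-5-yl for ethylcarbamoyl gives a number 25 percentage points higher from compound 1 to compound 4 (beyond the scatter), the first step read at this place on the ring of carbon only. It shows that the number responds to what sits at this place, and that a group with no ring, one hydrogen-bond donor and one hydrogen-bond acceptor can give a higher reading here than a ring with no hydrogen-bond donor and two hydrogen-bond acceptors. Nothing measured here accounts for the rise, and this single step cannot tell which of those differences matters.

The compounds shown leave open whether the amide hydrogen or the ethyl chain carries the step, a question that methylcarbamoyl, dimethylcarbamoyl or a longer propyl amide at the same place could help to separate. Also open, going by these compounds, is how a carboxylic acid or an amine would read at this place, and whether the step would hold at other doses of the same compounds.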